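This account rests on a few compounds, and the source may have more. Where it says the series, first, only, none or still open, it means among the compounds named here.

Of the compounds shown here, three built on the same core have been measured in an assay on isolated protein for binding affinity to Type-2 angiotensin II receptor (Homo sapiens); a lower number here means a stronger inhibitor, a higher number a weaker inhibitor. Compound 3 `CCCc1nc(CC)c(C(=O)OCc2ccccc2OC)n1Cc1ccc(-c2ccccc2S(=O)(=O)NC(=O)OCCC(C)C)cc1F` gives 1 nM in this assay, the lowest of the three numbers, though that distinction is not one the scatter supports. Compound 1 `CCCc1nc(CC)c(C(=O)OCCCOCc2ccccc2)n1Cc1ccc(-c2ccccc2S(=O)(=O)NC(=O)OCCC(C)C)cc1F` gives 2 nM in this assay, and compound 2 `CCCc1nc(CC)c(C(=O)OCC(=O)c2ccccc2)n1Cc1ccc(-c2ccccc2S(=O)(=O)NC(=O)OCCC(C)C)cc1F` gives 2 nM. The steps of no change at the digits printed from compound 1 to compound 2 (within the scatter), a 2.0-fold lower number from compound 1 to compound 3 (0.30 log units; within the scatter) and a 2.0-fold lower number from compound 2 to compound 3 (0.30 log units; within the scatter) all fall within the scatter, so exchanging the whole ester side chain among these three variants leaves the read-out essentially unmoved.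

Compound 4 `CCCc1nc(CC)c(C(=O)OCc2ccccc2OCCC(C)C)n1Cc1ccc(-c2ccccc2S(=O)(=O)NC(=O)OCCC(C)C)cc1F` differs from compound 3 in one place: isobutyl in place of hydrogen on a saturated chain carbon bound to an oxygen on an aromatic ring. Among the measured compounds shown here, none of the measured steps touches a group on an aromatic ring in this way; each swaps the entire side chain instead, so they bear on the question only indirectly. Since those larger exchanges produced no step beyond the scatter, the step from compound 3 to compound 4 is expected to be small as well, a 1.5-fold higher number from compound 3 to compound 4 (0.18 log units; within the scatter). Compound 4 is therefore estimated at 1.5 nM in this assay, within a range from 0.5 nM to 5 nM.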

Compound 4, half-maximal inhibitory concentration: 10 nM
Beside the measured number, compound 4's estimate is 6.7-fold (0.82 log units) below it, and the stated range ends below it.
By their numbers in this assay, from the lowest: compounds 3, 1 and 2 (each within the scatter of the next); then compound 4.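

In this assay, among the compounds shown here, lengthening methoxy to isopentyloxy on the aromatic ring gives a 10-fold higher number from compound 3 to compound 4 (1.00 log units; beyond the scatter) and so, unlike the earlier steps, moves the read-out beyond the scatter. The 2-(isopentyloxy)phenyl side chain also stands apart from the other two, with a 5.0-fold higher number from compound 2 to compound 4 (0.70 log units; beyond the scatter) and with a 5.0-fold higher number from compound 1 to compound 4 (0.70 log units; beyond the scatter) as well, so this ester side chain is not free to vary without limit, and a small extension at this one oxygen can matter more than exchanging the whole side chain among the earlier variants. Nothing available explains why the number rises.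

Going by these compounds, whether the number climbs gradually with chain length stays open, as ethoxy or propoxy would show. Also open, on these data alone, is how an amine or a carboxylic acid at the end of this chain would compare with the plain isopentyl chain.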